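The source may report more compounds than this note shows. Statements on the series, on what has been measured and on what is new or still open speak of the compounds shown alone.

- compound 1 `Cc1ccc(-c2nn(-c3ccccc3)cc2-c2nc3ccccc3n2S(=O)(=O)c2cc(C)ccc2C)cc1`: 82200 nM
- compound 2 `Cc1ccc(-c2nn(-c3ccccc3)cc2-c2nc3ccccc3n2S(=O)(=O)c2ccc(F)cc2)cc1`: 128000 nM
- compound 3 `Cc1ccc(-c2nn(-c3ccccc3)cc2-c2nc3ccccc3n2S(=O)(=O)c2ccc(C(F)(F)F)cc2)cc1`: 182000 nM

These three compounds share a core and differ in the aryl group on the sulfonyl sulfur. In an ADME assay on HEK-293T cells (Homo sapiens) for cytotoxicity, read by MTT assay, with a stated time of 24 h (on this read-out higher numbers stand for lower toxicity in this test and lower numbers for higher toxicity in this test), compound 1 gives 82200 nM, at the low end of the set. Its nearest neighbour is given by a 1.6-fold higher number from compound 1 to compound 2 (0.19 log units; within the scatter), and its furthest by a 2.2-fold higher number from compound 1 to compound 3 (0.35 log units; beyond the scatter).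

Compound 4 `Cc1ccc(C)c(S(=O)(=O)n2c(-c3cn(-c4ccccc4)nc3-c3ccc(C(F)(F)F)cc3)nc3ccccc32)c1` keeps the 2,5-dimethylphenyl group of compound 1 and changes the other end of the molecule: trifluoromethyl in place of methyl on an aromatic carbon. This places trifluoromethyl in place of methyl on an aromatic carbon, para to a large group.

Among the measured compounds shown here, no measured step makes this change at this place, so the evidence is indirect. Trifluoromethyl appears only on the sulfonyl aryl group, in a 2.2-fold higher number from compound 1 to compound 3 (0.35 log units; beyond the scatter) and in a 1.4-fold higher number from compound 2 to compound 3 (0.15 log units; within the scatter). Both steps are small and point upward, so only a small upward shift, probably not beyond the scatter, is expected in this assay.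

The expected step is a 1.3-fold higher number from compound 1 to compound 4 (0.11 log units; within the scatter).

For compound 4 the estimated value is 105000 nM, with an expected range from 55000 nM to 200000 nM.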

Compound 4, half-maximal cytotoxic concentration: 223000 nM
The estimate for compound 4 lay 2.1-fold (0.33 log units) below the measured number; measured number above the stated range.
By their numbers in this assay, from the lowest: compounds 1, 2, 3 and 4 (each within the scatter of the next, the first and the last beyond it).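

In this assay, among the compounds shown here, the step of a 2.7-fold higher number from compound 1 to compound 4 (0.43 log units; beyond the scatter) is the first measured change at the 4-methylphenyl end of the molecule, which stayed the same across compounds 1, 2 and 3. It shows that this end is not silent in this test: with the 2,5-dimethylphenyl group on the sulfonyl sulfur kept, one change on this aromatic carbon moves the number beyond the scatter, as the move from 2,5-dimethylphenyl to 4-(trifluoromethyl)phenyl on the sulfonyl sulfur also did. Nothing measured here bears on why the number moves.

As far as these compounds go, this reading rests on a single pair, so it remains open whether the same change would move the number with a 4-fluorophenyl group on the sulfonyl sulfur. The compounds shown also leave open how other groups at this place, such as chloro, methoxy or an amine, would compare with methyl and trifluoromethyl.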